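This account rests on a few compounds, and the source may have more. Where it says the series, first, only, none or still open, it means among the compounds named here.

Of the compounds shown here, three have so far been tested in a functional assay on the whole organism with Rattus norvegicus as the target, at a dose of 100 mg/kg; a lower number here means less inhibition, a higher number more inhibition at the dose given (going by the name of the read-out). Compound 1 `O=c1ccc(-c2ccccc2)nn1CCCCNC(=S)Nc1ccc(Cl)cc1` gives 43.2%, compound 2 `C/N=C(/NC#N)NCCCCn1nc(N(C)C)ccc1=O` gives 26.3%, and compound 3 `O=c1ccc(-c2ccccc2)nn1CCCC/N=C(\S)Nc1ccc(S(=O)(=O)O)cc1` gives 25.1%. On these numbers compound 2 stands second highest of the three: its value and that of compound 3 lie within the usual scatter of each other, while compound 1 sits higher by a margin beyond that scatter.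

Compound 4 `C/N=C(/NC#N)NCCCCn1nc(Nc2ccccc2)ccc1=O` has not yet been measured. It differs from compound 2 by anilino in place of dimethylamino on an aromatic carbon. Within the data shown here, no pair of measured compounds differing in one place exists to calibrate this change, so the step from compound 2 to compound 4 is expected to be small, of uncertain direction, and likely no larger than the scatter, as a number 3.7 percentage points higher from compound 2 to compound 4 (within the scatter) expresses. Compound 4 is therefore estimated to give about 30%, with a plausible range from 14% to 48%.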

Compound 4, a percentage reported as inhibition, in the whole organism at one dose (the size of the read-out at that dose, not a potency): 24.4%
Compound 4: middle estimate off by 5.6 percentage points, on the high side; measured number inside the range.
By their numbers in this assay, from the lowest: compounds 4, 3 and 2 (each within the scatter of the next); then compound 1.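

At this position on the aromatic carbon, anilino in place of dimethylamino gives a number 1.9 percentage points lower from compound 2 to compound 4 (within the scatter) in this assay. So the read-out does not separate the two groups, even though anilino brings more heavy atoms, a six-membered aromatic ring and a hydrogen-bond donor. Nothing measured here bears on why the two groups read alike.

From the compounds shown here alone, whether a simple amine or a carboxylic acid at this position would also read alike stays open. So does whether this change would hold with a longer chain.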